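Cytotoxicity expected to hold after one phenyl substituent change

This account rests on a few compounds, and the source may have more. Where it says the series, first, only, none or still open, it means among the compounds named here.

- compound 1 `COc1ccc(/C=C2\CCC/C(=C\c3ccc(Br)cc3)C2=O)cc1OC`: 4300 nM
- compound 2 `COc1ccc(/C=C2\CCC/C(=C\c3ccc(O)c(Cl)c3)C2=O)cc1OC`: 7600 nM

For the measured compounds named here, in a functional assay on HT-1080 cells (Homo sapiens) for cytotoxicity, read by MTT assay, with a stated time of 72 h (a lower number here means a stronger inhibitor, a higher number a weaker inhibitor), compound 2 gives 7600 nM, and no order can be drawn against the only other number. Compound 3 `COc1cc(/C=C2\CCC/C(=C\c3ccc(OC)c(OC)c3)C2=O)ccc1O` carries one change from compound 2, methoxy in place of chloro on an aromatic carbon, ortho to a hydroxy group. Going by the values given here, one measured step bears on this phenyl group, a 1.8-fold higher number from compound 1 to compound 2 (0.25 log units; within the scatter), with 3-chloro-4-hydroxyphenyl in place of 4-bromophenyl. Among the compounds with values here, no measured step covers this exact swap, so nothing beyond the scatter is expected in this assay. The expected step is a 1.3-fold lower number from compound 2 to compound 3 (0.10 log units; within the scatter). Compound 3 is expected at about 6000 nM, with an estimated range of 2500 nM to 15000 nM.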

Compound 3, half-maximal inhibitory concentration: 4600 nM
Beside the measured number, compound 3's estimate is 1.3-fold (0.12 log units) above it; the range from low to high includes it.
By their numbers in this assay, from the lowest: compounds 1, 3 and 2 (each within the scatter of the next).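

In this assay, methoxy in place of chloro on an aromatic carbon, ortho to a hydroxy group, gives a 1.7-fold lower number from compound 2 to compound 3 (0.22 log units; within the scatter) and so adds a second group at this position that stays within the scatter. The 4-hydroxy-3-methoxyphenyl in place of 4-bromophenyl gives a 1.1-fold higher number from compound 1 to compound 3 (0.03 log units; within the scatter) and likewise stays within it, so all three phenyl variants remain unseparated. No evidence is available on why these numbers lie so close. On these data alone, whether an amine or a carboxylic acid on this aromatic carbon would give a step beyond the scatter remains open.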